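The compounds below may be only part of what the source reports. "The series", "measured", "known", "first", "only" and "open" are said of these compounds alone.

Of the compounds shown here, three built on one shared core have been measured in a functional assay on Jurkat cells for inhibition of nuclear factor NF-kappa-B complex (Homo sapiens); a lower number here means a stronger inhibitor, a higher number a weaker inhibitor. Compound 1 `CCOC(=O)c1cnc(C)nc1NN1C(=O)C=C(C)C1=O` gives 16000 nM, compound 2 `CCOC(=O)c1cnc(-c2csc(C)n2)nc1NN1C(=O)C=C(C)C1=O` gives 8000 nM, and compound 3 `CCOC(=O)c1cnc(-c2cccc(OC)c2)nc1NN1C(=O)C=C(C)C1=O` gives 5000 nM. Compound 2 holds the second highest of these three numbers, and both its neighbours lie within the scatter: a 2.0-fold lower number from compound 1 to compound 2 (0.30 log units; within the scatter) and a 1.6-fold lower number from compound 2 to compound 3 (0.20 log units; within the scatter). On these data alone, compound 4 `CCOC(=O)c1cnc(-c2cc(Cl)cc(Cl)c2)nc1NN1C(=O)C=C(C)C1=O` is still untested and differs from compound 2 in one place: 3,5-dichlorophenyl in place of 2-methyl-1,3-thiazol-4-yl on an aromatic carbon. For the measured compounds named here, the nearest precedent is the exchange of 2-methyl-1,3-thiazol-4-yl for 3-methoxyphenyl, which stayed within the scatter, while a 3.2-fold lower number from compound 1 to compound 3 (0.51 log units; beyond the scatter) was modest. A small step, if any, is therefore expected in this assay, estimated as a 1.8-fold lower number from compound 2 to compound 4 (0.25 log units; within the scatter). Compound 4 is expected to give about 4500 nM, within 1500 nM to 13000 nM.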

Compound 4, half-maximal inhibitory concentration: 300 nM
Beside the measured number, compound 4's estimate is 15-fold (1.18 log units) above it; measured number outside the range, below it.
By their numbers in this assay, from the lowest: compound 4; then compounds 3, 2 and 1 (each within the scatter of the next, the first and the last beyond it).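

In this assay, for the compounds shown here, this position, para to an ethoxycarbonyl group, proves far more responsive than the earlier compounds suggested: 3,5-dichlorophenyl brings a 27-fold lower number from compound 2 to compound 4 (1.43 log units; beyond the scatter) and a 17-fold lower number from compound 3 to compound 4 (1.22 log units; beyond the scatter) and, against the original methyl, a 53-fold lower number from compound 1 to compound 4 (1.73 log units; beyond the scatter) as well. The gain therefore depends on which ring stands here, not merely on a ring being present. Nothing available explains this jump.

On these data alone, whether both chlorines are needed remains open. So does whether a single chlorine, two bromines or two trifluoromethyl groups would match them, or how an amine or a carboxylic acid on this ring would fare.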